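The source may hold more compounds than are shown below. What is called first, only, known or untested is meant among the compounds shown, and "the series" means these compounds.

Measured compounds: compound 1 `COc1ccc(CCOc2ccc(-c3c(C)nc(C)c([C@H](OC(C)(C)C)C(=O)O)c3N3CCC(C)(C)CC3)cc2)cc1`, compound 2 `Cc1cc(CCOc2ccc(-c3c(C)nc(C)c([C@H](OC(C)(C)C)C(=O)O)c3N3CCC(C)(C)CC3)cc2)ccc1F`, compound 3 `Cc1nc(C)c([C@H](OC(C)(C)C)C(=O)O)c(N2CCC(C)(C)CC2)c1-c1ccc(OCCc2cc(F)ccc2F)cc1`.

In an ADME assay on the whole organism (Rattus norvegicus, strain Sprague-Dawley) for pharmacokinetics, read by LC-MS, at a dose of 1 mg/kg by the intravenous route (on this read-out lower numbers stand for slow clearance and higher numbers for fast clearance), compound 1 gives 13.4 mL/min/kg. Compound 2 gives 7.8 mL/min/kg. Compound 3 gives 18.7 mL/min/kg. Compound 3 sits beyond the scatter only against compound 2, as a 2.4-fold higher number from compound 2 to compound 3 (0.38 log units; beyond the scatter) shows; against compound 1 the step of a 1.4-fold higher number from compound 1 to compound 3 (0.14 log units; within the scatter) stays within the scatter, as does a 1.7-fold lower number from compound 1 to compound 2 (0.24 log units; within the scatter). Compound 4 `Cc1ncsc1CCOc1ccc(-c2c(C)nc(C)c([C@H](OC(C)(C)C)C(=O)O)c2N2CCC(C)(C)CC2)cc1` has not yet been measured; it carries 4-methyl-1,3-thiazol-5-yl in place of 2,5-difluorophenyl on a saturated chain carbon, two bonds along the chain from an oxygen on an aromatic ring. All three measured steps swap the aryl group at this same place, and each moved the number only modestly. Among the compounds with values here, no measured step brings in a five-membered ring with hetero atoms, so the direction is uncertain; the expected step is a 1.4-fold lower number from compound 3 to compound 4 (0.16 log units; within the scatter), probably within the scatter. Compound 4 is therefore estimated at 13 mL/min/kg, with a range from 6 mL/min/kg to 28 mL/min/kg.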

Compound 4, clearance: 69 mL/min/kg
Estimate against measurement, compound 4: 5.3-fold (0.72 log units) below; measured number above the stated range.
By their numbers in this assay, from the lowest: compounds 2, 1 and 3 (each within the scatter of the next, the first and the last beyond it); then compound 4.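

Among the substituted phenyl rings at this place on the chain, the widest step in this assay was a 2.4-fold higher number from compound 2 to compound 3 (0.38 log units; beyond the scatter), but 4-methyl-1,3-thiazol-5-yl goes well past it, with a 3.7-fold higher number from compound 3 to compound 4 (0.57 log units; beyond the scatter), a 5.1-fold higher number from compound 1 to compound 4 (0.71 log units; beyond the scatter) and an 8.8-fold higher number from compound 2 to compound 4 (0.95 log units; beyond the scatter). So the number depends on more than which substituents a phenyl ring carries, and this five-membered ring with two hetero atoms gives the highest clearance of the four compounds. Nothing measured here explains the rise.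

Going by these compounds, it remains open whether the rise belongs to the thiazole ring itself or to its methyl group. On these data alone, it is also open whether a pyridine ring at this place would track the phenyl rings or the thiazole.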